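This account rests on a few compounds, and the source may have more. Where it says the series, first, only, none or still open, it means among the compounds named here.

Measured compounds:
- compound 1 `Cc1cc(Cl)c2c(c1O)C(=O)C=CC2=O` — in a functional assay on HeLa cells (Homo sapiens) for cytotoxicity, read by XTT assay, with a stated time of 24 h (on this read-out lower numbers stand for stronger inhibition and higher numbers for weaker inhibition), compound 1 gives 10100 nM
- compound 2 `COc1c(C)cc(Cl)c2c1C(=O)C=CC2=O` — in this assay compound 2 gives 41500 nM
- compound 3 `COc1cc(C)c(Cl)c2c1C(=O)C=CC2=O` — in this assay compound 3 gives 19100 nM

Compound 4 `Cc1cc(O)c2c(c1Cl)C(=O)C=CC2=O` is not yet measured. Compound 2 and compound 3 carry the same atoms joined differently; the difference between the two cores is not broken down here. The change from compound 3 to compound 4 is hydrogen in place of methyl on an oxygen on an aromatic ring. The same change is seen once among the measured compounds, from compound 2 to compound 1, as hydrogen in place of methyl on an oxygen on an aromatic ring, where it gave a 4.1-fold lower number from compound 2 to compound 1 (0.61 log units; beyond the scatter). On that single precedent, the step from compound 3 to compound 4 in this assay is expected to be of similar size, about a 3.2-fold lower number from compound 3 to compound 4 (0.50 log units; beyond the scatter), though it rests on one pair alone and the cores differ. Compound 4 is therefore estimated at 6000 nM, with a likely range from 2500 nM to 15000 nM.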

Compound 4, half-maximal inhibitory concentration: 13500 nM
The estimate for compound 4 lay 2.3-fold (0.35 log units) below the measured number; the range from low to high includes it.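

In this assay, methoxy to hydroxy gives a 1.4-fold lower number from compound 3 to compound 4 (0.15 log units; within the scatter) and so leaves no clear step on this core. The size of the change does not carry over unchanged from one core to the other: the same change on two cores in this assay, a 4.1-fold lower number (0.61 log units; beyond the scatter) from compound 2 to compound 1 and a 1.4-fold lower number (0.15 log units; within the scatter) from compound 3 to compound 4, 2.9-fold (0.46 log units) apart, beyond the scatter of two such steps. These two pairs show that the step depends on the core in this series, but not which difference between the cores sets the gap, nor what the change would do on a further core.

On these data alone, only methoxy and hydroxy are compared here, so the reading for an ethoxy group or an amine in their place remains open. Also open, as far as these compounds go, is how bromine or a nitrile in place of the chlorine would read on either core.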